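Benzylamine variations on a dihydroxychromenone core: cytotoxicity notes

The source may report more compounds than this note shows. Statements on the series, on what has been measured and on what is new or still open speak of the compounds shown alone.

Measured so far in an ADME assay on Huh-7 cells (Homo sapiens) for cytotoxicity; on this read-out lower numbers stand for higher toxicity in this test and higher numbers for lower toxicity in this test:
- compound 1 `O=c1cc(CNCc2ccccc2[N+](=O)[O-])oc2ccc(O)c(O)c12`: 41300 nM
- compound 2 `O=c1cc(CNCc2cccc(F)c2)oc2ccc(O)c(O)c12`: limit of the assay, > 100000 nM
- compound 3 `O=c1cc(CNCc2cccc([N+](=O)[O-])c2)oc2ccc(O)c(O)c12`: limit of the assay, > 100000 nM

Compound 2 stands only at a limit in this assay; no number is known for it. Compound 3 sits at the same limit, so the step from compound 2 to compound 3 is a step that the two limits leave unreadable from compound 2 to compound 3. Among the compounds with values here, compound 1 is the one compound with a number in this assay. Two of the three values shown sit at the limit of > 100000 nM in this assay, at which 2 of the 3 values shown sit.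

The unmeasured compound 4 `O=c1cc(CNCc2ccc(Cl)cc2)oc2ccc(O)c(O)c12` differs from compound 2 by 4-chlorophenyl in place of 3-fluorophenyl on a saturated chain carbon bound to an amine nitrogen. Within the data shown here, no measured step covers this change: the only step available is the unreadable one from compound 2 to compound 3, and the pair of compound 1 and compound 2 shows a number against a limit, which bears on it only loosely. With two of three compounds at the limit and the third not far from it, compound 4 is expected at or near the limit too, so the step from compound 2 to compound 4 is estimated as a number no higher from compound 2 to compound 4 (the limit leaves the size open). Compound 4 is therefore estimated at 100000 nM, with a range from 40000 nM to 200000 nM, most likely reported as a limit.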

Compound 4, half-maximal cytotoxic concentration: > 100000 nM
Compound 4: a limit, no number; the forecaster's own chance of this, stated with the estimate: 60%; the middle value sits exactly at the limit.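

Compound 2 and compound 4 both stand at a limit, not a number, so no step between them can be read: the limit of > 100000 nM in this assay, at which 3 of the 4 values shown sit.

The compounds shown leave open what number compound 2, compound 3 and compound 4 carry, and whether 4-chlorophenyl in place of 3-fluorophenyl changes the read-out at all.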